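The compounds below may be only part of what the source reports. "The series", "measured", "known", "first", "only" and "open" are said of these compounds alone.

Compound 1 `Cc1cc(-n2ccc3cccnc32)cn2c(CSCCc3ccccc3)cnc12` and compound 2 `Cc1cc(C#N)cn2c(CSCCc3ccccc3)cnc12` share one core, while compound 3 `Cc1cc(-n2ccc3cccnc32)c2ncc(CSCCc3ccccc3)n2c1` is built from the same atoms joined into a different core; how the two cores differ is not broken down here. In an ADME assay on HEL cells (Homo sapiens) for cytotoxicity, with a stated time of 3 days (a higher number here means that more compound is tolerated, a lower number that less compound is tolerated), compound 1 gives 20 ug/mL. In this assay compound 2 gives 20 ug/mL. In this assay compound 3 gives 100 ug/mL, the highest of the three numbers, and its gap to each of the other two lies beyond the scatter. The change from compound 1 to compound 2 is a group of 2 heavy atoms (1 carbon, 1 nitrogen; no ring) in place of a group of 9 heavy atoms (7 carbon, 2 nitrogen; one five-membered aromatic ring with 1 hetero atom, one six-membered aromatic ring with 1 hetero atom), on an aromatic carbon with no change at the digits printed from compound 1 to compound 2 (within the scatter). Compound 4 `Cc1cc(C#N)c2ncc(CSCCc3ccccc3)n2c1` carries the same kind of change on the core of compound 3: a group of 2 heavy atoms (1 carbon, 1 nitrogen; no ring) in place of a group of 9 heavy atoms (7 carbon, 2 nitrogen; one five-membered aromatic ring with 1 hetero atom, one six-membered aromatic ring with 1 hetero atom), on an aromatic carbon. The two places are not identical: in compound 1 the place is para to a fused ring, whereas in compound 3 it is ortho to a fused ring. Because no change at the digits printed from compound 1 to compound 2 (within the scatter), a step of about the same size is expected here, no change at the digits printed from compound 3 to compound 4 (within the scatter), although this rests on one measured pair alone. Compound 4 is therefore estimated at 100 ug/mL in this assay, most likely between 30 ug/mL and 200 ug/mL.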

Compound 4, minimum cytotoxic concentration: >= 20 ug/mL
Compound 4 was reported as a limit; the forecaster's own chance of this, stated with the estimate: 20%; the middle value does not contradict the limit.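

The step between compound 3 and compound 4 cannot be read, because compound 4 is reported only as a limit in this assay: the limit of >= 20 ug/mL in this assay, at which 1 of the 4 values shown sits.

The compounds shown leave open whether cyano in this place alters the number on the core of compound 3, or leaves it unchanged, as it does on the core of compound 1.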